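Fluoro for Hydrogen on Two Related Cores

This account rests on a few compounds, and the source may have more. Where it says the series, first, only, none or still open, it means among the compounds named here.

Compound 1, `Cn1cnc2c(Nc3ccccc3)ncnc21`: 0%
Compound 2, `Cn1cnc2c(Nc3ccc(F)cc3)ncnc21`: 8%
Compound 3, `Cn1cnc2c(-c3ccccc3)ncnc21`: 8%

All three were tested in an assay on isolated protein for inhibition of Ca2+/calmodulin-dependent protein kinase II (CaM kinase II) (Rattus norvegicus), tested at 30 uM; on this read-out higher numbers stand for more inhibition at the one concentration tested (going by the name of the read-out) and lower numbers for less inhibition. Compound 1 and compound 2 share a core and differ by one change, (fluoro in place of hydrogen on an aromatic carbon). That change made a step of a number 8 percentage points higher from compound 1 to compound 2 (within the scatter), so the two numbers cannot be told apart. Compound 3 carries a different core; the difference between the two cores is not broken down here. In this assay compound 3 gives 8%, level with compound 2 and within the scatter of compound 1, so none of the three can be called more or less inhibiting than another.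

Compound 4, `Cn1cnc2c(-c3ccc(F)cc3)ncnc21`, has not yet been measured. It differs from compound 3 by fluoro in place of hydrogen on an aromatic carbon, the same change as from compound 1 to compound 2, at the same kind of place. Because the earlier step was a number 8 percentage points higher from compound 1 to compound 2 (within the scatter), a step of similar size, a number 4 percentage points higher from compound 3 to compound 4 (within the scatter), is expected from compound 3 to compound 4. For compound 4 the estimate is 12%, with a likely range from 0% to 25%.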

Compound 4, a percentage reported as inhibition, at one concentration (the size of the read-out at that concentration, not a potency): 12%
The estimate for compound 4 equals the measured number at the digits printed; measured number inside the range.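

In this assay, fluoro in place of hydrogen on an aromatic carbon gave a number 4 percentage points higher from compound 3 to compound 4 (within the scatter). Set beside the earlier step on the other core, the new step cannot be told apart from it: the same change on two cores in this assay, a number 8 percentage points higher (within the scatter) from compound 1 to compound 2 and a number 4 percentage points higher (within the scatter) from compound 3 to compound 4, 4 percentage points apart, within the scatter of two such steps

The change therefore behaves alike on the two cores as far as this read-out can tell, but each step lies within the scatter, so this does not show that fluoro alters inhibition on either core, nor that a real effect of the change would carry from one core to the other.

Going by these compounds, what an amine, a carboxylic acid or a longer chain would do at the same place on either core remains open. Also open, on these data alone, is whether any such group could move inhibition clearly beyond the scatter, and whether the steps on the two cores would still match if it did.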